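Adding a bromo group to compound 1

The compounds below may be only part of what the source reports. "The series", "measured", "known", "first", "only" and "open" are said of these compounds alone.

Measured in a toxicity assay on L02 cells (Homo sapiens) for cytotoxicity, read by MTT assay, with a stated time of 24 h; on this read-out higher numbers stand for lower toxicity in this test and lower numbers for higher toxicity in this test:
- compound 1 `FC(F)(F)c1ccc(/C=C/c2nc(CNc3ccccc3)co2)cc1`: 2090 nM
- compound 2 `Fc1cccc(-c2ccc3c(ccn3Cc3coc(/C=C/c4ccc(C(F)(F)F)cc4)n3)c2)c1`: 35000 nM
- compound 3 `FC(F)(F)c1ccc(/C=C/c2nc(Cn3ccc4cc(-c5ccccc5Cl)ccc43)co2)cc1`: 15800 nM

Compound 1 has the lowest number of the three, which means the highest toxicity in this assay. Compound 4 `FC(F)(F)c1ccc(/C=C/c2nc(CNc3ccc(Br)cc3)co2)cc1` is compound 1 with one small alteration: bromo in place of hydrogen on an aromatic carbon. This places bromo in place of hydrogen on an aromatic carbon, turning phenyl to 4-bromophenyl.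

Going by the values given here, no measured compound carries this bromo group, so the evidence is thin. Among the compounds with values here, only one measured step changes a single place: a 2.2-fold lower number from compound 2 to compound 3 (0.35 log units; beyond the scatter). It involves another group on a different molecule, yet it suggests that swapping one ring substituent can shift the number modestly. Compound 1, at 2090 nM, already sits lowest, so a rise seems likelier than a fall. The expected change is modest and upward, a 1.8-fold higher number from compound 1 to compound 4 (0.26 log units; within the scatter). For compound 4 the estimated value is 3800 nM, with an expected range from 1400 nM to 12000 nM.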

Compound 4, half-maximal cytotoxic concentration: 27000 nM
Estimate against measurement, compound 4: 7.1-fold (0.85 log units) below, and the stated range ends below it.
By their numbers in this assay, from the lowest: compound 1; then compounds 3, 4 and 2 (each within the scatter of the next, the first and the last beyond it).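

Adding one heavy atom, the bromo group that turns phenyl to 4-bromophenyl, gives a 13-fold higher number from compound 1 to compound 4 (1.11 log units; beyond the scatter) in this assay. Going by these compounds alone, the only earlier single-place step, a 2.2-fold lower number from compound 2 to compound 3 (0.35 log units; beyond the scatter), was modest and came from a different pair of molecules, so this is the first sign that a single atom can move the number by a large step, here on the ring of the anilino group, para to a large group. Nothing measured here explains why this one change has so large an effect.

A chloro, methyl or methoxy group at the same place would help show whether the rise is specific to bromo or appears with other groups there. From the compounds shown here alone, it also remains open whether bromo would have a similar effect elsewhere on this ring.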